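Cyclobutylamino replaces the carboxycyclopentenyl group on a xanthine core

The source may hold more compounds than are shown below. What is called first, only, known or untested is meant among the compounds shown, and "the series" means these compounds.

Of the compounds shown here, three sharing one core have been tested in a functional assay for antagonist activity at adenosine receptor A1 (Homo sapiens); on this read-out higher numbers stand for weaker inhibition and lower numbers for stronger inhibition. Compound 1 `CCCn1c(=O)c2nc([C@H]3CC[C@H](CNC(C)=O)CC3)[nH]c2n(CCC)c1=O` gives 8 nM in this assay. Compound 2 `CCCn1c(=O)c2nc(C3CCCC3C(=O)N(C)CCN(C)C)[nH]c2n(CCC)c1=O` has several entries in this assay, 53 nM; > 3000 nM (2 entries), and the spread among them is shown by the several entries of compound 2 in this assay, 53 nM; > 3000 nM (2 entries). For compound 3 `CCCn1c(=O)c2nc(C3=C(C(=O)O)CCC3)[nH]c2n(CCC)c1=O` this assay reports only a limit, > 10000 nM, so no single number is known, as noted in the limit of > 10000 nM in this assay, at which 1 of the 3 values shown sits. Compound 3 thus stands at the weak end of the values shown, with nothing more than a boundary.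

Compound 4 `CCCn1c(=O)c2nc(NC3CCC3)[nH]c2n(CCC)c1=O` differs from compound 3 in one place: cyclobutylamino in place of 2-carboxycyclopent-1-en-1-yl on an aromatic carbon. The amino-linked small ring resembles the ring-bearing groups of compound 1 more than the acid-bearing group of compound 3. The expected step is an at least 100-fold lower number from compound 3 to compound 4 (2.00 log units; beyond the scatter), a gain in inhibition well beyond the usual scatter, because compound 1 reaches 8 nM with a ring at the same position. Compound 4 is therefore expected to give about 100 nM in this assay, with a plausible range from 10 nM to 1000 nM.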

Compound 4, inhibition constant: 2.6 nM
Estimate against measurement, compound 4: 38-fold (1.59 log units) above; the measured number lies below the stated range.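

In this assay, the aromatic carbon between two ring nitrogen atoms responds very strongly to the group it carries: replacing 2-carboxycyclopent-1-en-1-yl with cyclobutylamino gives an at least 3800-fold lower number from compound 3 to compound 4 (3.58 log units; beyond the scatter). Compound 3 gives > 10000 nM, which is a limit and not a number, so this step is a minimum. Both groups have 1 hydrogen-bond donor, 1 hydrogen-bond acceptor and no net charge, so these counts do not separate them.

This single change removes the carboxy group, replaces the five-membered ring with a four-membered one and brings in a nitrogen link all at once, so the compounds shown cannot tell which of these differences matters. A cyclopentylamino group, or a cyclobutyl ring joined directly to the aromatic carbon, would help to pull these differences apart.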